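The source may hold more compounds than are shown below. What is called first, only, known or untested is meant among the compounds shown, and "the series" means these compounds.

Measured compounds:
compound 1 `O=C(Nc1cc(Sc2ncn[nH]2)c(O)c2ccccc12)c1cccc(Cl)c1`: 85600 nM in a functional assay on PC-3 cells (Homo sapiens) for antiproliferative activity, read by MTT assay, with a stated time of 48 h; on this read-out lower numbers stand for stronger inhibition and higher numbers for weaker inhibition.
compound 2 `COc1ccc(/C=C/C(=O)Nc2cc(Sc3ncn[nH]3)c(O)c3ccccc23)cc1OC`: > 100000 nM, a limit of the assay, not a number.
compound 3 `O=C(Nc1cc(Sc2nncs2)c(O)c2ccccc12)c1ccc(Cl)cc1`: > 100000 nM, likewise a limit.

On the numbers shown, compound 2 stands at the limit of this assay rather than at a value. Only compound 1 gives a number at all, and a weak one. The other limit is a shared feature: the limit of > 100000 nM in this assay, at which 2 of the 3 values shown sit.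

Compound 4 `O=C(/C=C/c1ccccc1)Nc1cc(Sc2ncn[nH]2)c(O)c2ccccc12` differs from compound 2 by phenyl in place of 3,4-dimethoxyphenyl on a double-bonded chain carbon bound to a double-bonded chain carbon, phenyl in place of 3,4-dimethoxyphenyl. For the measured compounds named here, no pair of measured compounds differs in one place, so no measured step sets the size of this change. The step of a number no higher from compound 2 to compound 4 (the limit leaves the size open) is expected to be none beyond the scatter, since compound 2 sits at a limit. Compound 4 is therefore expected near 100000 nM, within 40000 nM to 250000 nM, most likely reported again as a limit.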

Compound 4, half-maximal inhibitory concentration: > 100000 nM
Compound 4 ended at the assay's limit; the forecaster's own chance of this, stated with the estimate: 65%; the middle value sits exactly at the limit.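

In this assay, phenyl in place of 3,4-dimethoxyphenyl leaves compound 4 at a limit of the assay, and the step from compound 2 cannot be read, as both values are limits. On the carbonyl carbon, 2-phenylethenyl in place of 3-chlorophenyl gives an at least 1.1-fold higher number from compound 1 to compound 4 (0.06 log units; that floor lies within the scatter), so no real difference between these two groups is established. The series now resolves little in this assay: the limit of > 100000 nM in this assay, at which 3 of the 4 values shown sit.

Still open, as far as these compounds go, is whether an amine or a carboxylic acid on that phenyl would bring a value inside the range of the assay. Also open, from the compounds shown here alone, is what a longer chain in place of 2-phenylethenyl would do.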